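Hydroxy returns at a new position on the aryl ring

This account rests on a few compounds, and the source may have more. Where it says the series, first, only, none or still open, it means among the compounds named here.

For the measured compounds named here, compound 2 `COc1cc(OC)cc(-c2cc3ccccc3c(-c3cccc(N)c3)n2)c1` gives 13200 nM in a functional assay on DU-145 cells (Homo sapiens) for cytotoxicity, read by CCK-8 assay and cell counting, with a stated time of 72 h (a higher number here means a weaker inhibitor, a lower number a stronger inhibitor), the highest of the two numbers so far; compound 1 `COc1cc(OC)cc(-c2cc3ccccc3c(-c3cccc(O)c3)n2)c1` gives 3870 nM. Going by the values given here, the only step seen is a 3.4-fold higher number from compound 1 to compound 2 (0.53 log units; beyond the scatter). Compound 3 `COc1cc(OC)cc(-c2cc3ccccc3c(-c3ccc(O)cc3)n2)c1` carries 4-hydroxyphenyl in place of 3-aminophenyl on an aromatic carbon, which brings back a hydroxy group, though on a different carbon of the phenyl ring. Since the hydroxy-bearing compound 1 gave 3870 nM, compound 3 is expected to show a lower number than compound 2, an estimated step of a 2.9-fold lower number from compound 2 to compound 3 (0.47 log units; beyond the scatter). Compound 3 is therefore estimated at 4500 nM, within 1500 nM to 13000 nM.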

Compound 3, half-maximal inhibitory concentration: 4580 nM
For compound 3 the middle estimate is 1.0-fold (0.01 log units) below the measured one; the measured number falls inside the stated range.
By their numbers in this assay, from the lowest: compounds 1 and 3 (each within the scatter of the next); then compound 2.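

With 4-hydroxyphenyl in place of 3-aminophenyl in this assay, there is a 2.9-fold lower number from compound 2 to compound 3 (0.46 log units; beyond the scatter), so a hydroxy group at this position again gives a number on the side of compound 1. The hydroxy group's location on the phenyl ring cannot be told apart here: 4-hydroxyphenyl in place of 3-hydroxyphenyl gives a 1.2-fold higher number from compound 1 to compound 3 (0.07 log units; within the scatter), and the two hydroxy compounds stand level. Still open, going by these compounds, is how a methoxy group or a carboxylic acid on this phenyl ring would read. No evidence is available to explain these results.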